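This account rests on a few compounds, and the source may have more. Where it says the series, first, only, none or still open, it means among the compounds named here.

Measured so far:
Compound 1 `O=C(NCCCCN1CCN(c2ccc(Cl)cc2)CC1)c1ccc(-c2ccsc2)cc1` gives 0.837 h in an ADME assay on microsomes from liver (Rattus norvegicus) for metabolic stability, read by LC-MS, using NADPH; on this read-out higher numbers stand for a longer-lived compound and lower numbers for a shorter-lived compound.
Compound 2 `O=C(NCCCCN1CCN(c2ccccc2O)CC1)c1ccc(-c2ccsc2)cc1` gives 0.157 h in this assay.

Among the measured compounds shown here, compound 2 stands at the lower of the two numbers in this assay; the one measured step, a 5.3-fold lower number from compound 1 to compound 2 (0.73 log units; beyond the scatter), separates it from compound 1, which gives the higher number. That step, with 2-hydroxyphenyl in place of 4-chlorophenyl on an amine nitrogen in a ring, is the only one that bears on the next compound.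

Compound 3 `N#Cc1ccc(N2CCN(CCCCNC(=O)c3ccc(-c4ccsc4)cc3)CC2)cc1` differs from compound 2 in one place: 4-cyanophenyl in place of 2-hydroxyphenyl on an amine nitrogen in a ring. The change removes the 2-hydroxyphenyl that went with the drop from compound 1 to compound 2 and puts a 4-cyanophenyl in its place. For the measured compounds named here, no measured step shows how 4-cyanophenyl compares with 4-chlorophenyl, so the size of the move is uncertain. Because the step of a 5.3-fold lower number from compound 1 to compound 2 (0.73 log units; beyond the scatter) was beyond the scatter, the return to a 4-substituted phenyl is expected to raise the number, with a 3.2-fold higher number from compound 2 to compound 3 (0.50 log units; beyond the scatter) as the estimated step.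

Compound 3 is therefore estimated at 0.5 h in this assay, with a range from 0.2 h to 1.2 h.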

Compound 3, half-life: 0.22 h
For compound 3 the middle estimate is 2.3-fold (0.36 log units) above the measured one; low and high end bracket the measured number.
By their numbers in this assay, from the lowest: compounds 2 and 3 (each within the scatter of the next); then compound 1.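

In this assay, the 2-hydroxyphenyl group on the amine nitrogen in the ring and the 4-cyanophenyl group give a 1.4-fold higher number from compound 2 to compound 3 (0.15 log units; within the scatter) and so cannot be told apart, which shows that the low number of compound 2 is not tied to 2-hydroxyphenyl alone. With the group held as a 4-substituted phenyl, cyano in place of chloro on an aromatic carbon gives a 3.8-fold lower number from compound 1 to compound 3 (0.58 log units; beyond the scatter) and thus shows that the substituent itself matters at this position, with compound 1 standing apart from both other compounds. Nothing measured here accounts for this difference between chloro and cyano.

With only three aryl groups shown, it remains open whether 4-chlorophenyl is unusual among 4-substituted phenyl groups or whether 4-fluorophenyl, 4-methoxyphenyl or plain phenyl would stand with it, and whether 2-chlorophenyl would match compound 1 or compound 2. From the compounds shown here alone, it also remains open whether the gap between chloro and cyano would persist on a longer chain between the amide and the ring nitrogen.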